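A few compounds are considered here, and "the series" means these few. Any claim that something is new, unique, unknown or untested is made for them only; others in the source may bear on it.

Compound 1 `O=S1(=O)c2ccccc2CN1c1cc(F)cc(Oc2cccnc2)c1` gives > 100000 nM in a functional assay on Flp-In T-REx293 cells for antagonist activity at Free fatty acid receptor 1 (Homo sapiens), read by calcium flux; on this read-out lower numbers stand for stronger inhibition and higher numbers for weaker inhibition.
Compound 2 `O=S1(=O)c2ccccc2CN1c1cccc(Oc2ccccc2)c1` gives 174 nM in this assay.

Of these two, only compound 2 has a measured number in this assay. Compound 1 does not: its result is a limit of the assay, and it sits at the limit described by the limit of > 100000 nM in this assay, at which 1 of the 2 values shown sits, so all that is known is that compound 1 is a weak inhibitor at the concentrations tested. Compound 3 `N#Cc1ccccc1Oc1cc(F)cc(N2Cc3ccccc3S2(=O)=O)c1` has not yet been measured in this assay. It differs from compound 1 in one place: 2-cyanophenyl in place of pyridin-3-yl on an oxygen on an aromatic ring. Among the measured compounds shown here, the core and the fluorine stay the same, and the only change is the ring carried on the ether oxygen, which is no longer the ring with one nitrogen atom but a carbon-only ring bearing a nitrile.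

Because compound 1 is known only from the limit (the limit of > 100000 nM in this assay, at which 1 of the 2 values shown sits), the size of the step from it cannot be fixed closely, but a move toward stronger inhibition is expected, roughly an at least 50-fold lower number from compound 1 to compound 3 (1.69 log units; beyond the scatter). For compound 3 the estimate in this assay is 2000 nM, expected to fall between 200 nM and 30000 nM.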

Compound 3, half-maximal inhibitory concentration: > 100000 nM
Compound 3 ended at the assay's limit; the forecaster's own chance of this, stated with the estimate: 30%; at least 50-fold (1.69 log units) between middle value and limit.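

Among the compounds shown here, compound 1 and compound 3 both rest at a limit of the assay and not at a number, so no step between them can be read: the limit of > 100000 nM in this assay, at which 2 of the 3 values shown sit.

From the compounds shown here alone, whether 2-cyanophenyl in place of pyridin-3-yl on the ether oxygen changes inhibition at all, and by how much, stays open in this assay.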